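Bromination of the coumarin-side ring in the quinolinone series

The compounds below may be only part of what the source reports. "The series", "measured", "known", "first", "only" and "open" are said of these compounds alone.

The shared core is seen in compound 1 `Cc1cccc2c(CNc3nc(-c4cc5cc(Br)ccc5oc4=O)cs3)cc(=O)[nH]c12`, in compound 2 `O=c1cc(CNc2nc(-c3cc4cc(Br)cc(Br)c4oc3=O)cs2)c2ccc(Cl)cc2[nH]1` and in compound 3 `O=c1cc(CNc2nc(-c3cc4cc(Br)ccc4oc3=O)cs2)c2ccc(Cl)cc2[nH]1`. In a functional assay on the whole organism for inhibition, with Rattus norvegicus as the target, read by paw edema, in the formalin test, with a stated time of 24 h, at a dose of 100 mg/kg by the intraperitoneal route (on this read-out higher numbers stand for more inhibition at the one dose given (going by the name of the read-out) and lower numbers for less inhibition), compound 1 gives 16.9%, compound 2 gives 10.6% and compound 3 gives 18.4%. Compound 1 stands between the other two on these numbers, and both gaps lie within the scatter. Among the compounds with values here, the one step measured so far, a number 7.8 percentage points higher from compound 2 to compound 3 (within the scatter), is the reverse of the change now considered.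

Compound 4 `Cc1cccc2c(CNc3nc(-c4cc5cc(Br)cc(Br)c5oc4=O)cs3)cc(=O)[nH]c12` differs from compound 1 by bromo in place of hydrogen on an aromatic carbon. Going by the step from compound 2 to compound 3 read backwards, a small drop, not beyond the scatter, is expected in this assay, a number 6.9 percentage points lower from compound 1 to compound 4 (within the scatter). The expected value for compound 4 is therefore 10%, in the range 0% to 22%.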

Compound 4, a percentage reported as inhibition, in the whole organism at one dose (the size of the read-out at that dose, not a potency): 9.78%
Estimate against measurement, compound 4: 0.2 percentage points above; the measured number falls inside the stated range.
By their numbers in this assay, from the lowest: compounds 4, 2, 1 and 3 (each within the scatter of the next).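

Bromo in place of hydrogen on this aromatic carbon, ortho to a fused ring and meta to a bromo group, now has a reading on the core of compound 1: in this assay the step is a number 7.1 percentage points lower from compound 1 to compound 4 (within the scatter). The same change thus stands on two cores, and the two steps agree: the same change on two cores in this assay, a number 7.8 percentage points higher (within the scatter) from compound 2 to compound 3 and a number 7.1 percentage points higher (within the scatter) from compound 4 to compound 1, 0.7 percentage points apart, within the scatter of two such steps

As far as these compounds go, neither step leaves the scatter, so whether this bromo has any real effect on the read-out stays open. From the compounds shown here alone, what an amine or a carboxylic acid on the same carbon would give also stays open.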